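Aryl change on an aromatic nitrogen: compound 3 to compound 4

The compounds below may be only part of what the source reports. "The series", "measured", "known", "first", "only" and "open" are said of these compounds alone.

Measured so far:
Compound 1 `Cc1ccccc1-n1nncc1CN1C(=O)C2(C(C#N)=C(N)Oc3c(N)cc4nc5ccccc5nc4c32)c2ccccc21`: in an ADME assay on L02 cells (Homo sapiens) for antiproliferative activity, read by MTT assay, with a stated time of 48 h (a higher number here means a weaker inhibitor, a lower number a stronger inhibitor), compound 1 gives > 50000 nM, which is a limit of the assay and not a number.
Compound 2 `N#CC1=C(N)Oc2c(N)cc3nc4ccccc4nc3c2C12C(=O)N(Cc1cnnn1-c1ccc(F)cc1)c1ccccc12`: in this assay compound 2 gives > 50000 nM, again a limit.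
Compound 3 `N#CC1=C(N)Oc2c(N)cc3nc4ccccc4nc3c2C12C(=O)N(Cc1cnnn1-c1c(F)cccc1F)c1ccccc12`: in this assay compound 3 gives > 50000 nM, again a limit.

Compound 3 therefore stands where every value in the series stands, namely at the limit of > 50000 nM in this assay, at which 3 of the 3 values shown sit. The three steps a step that the two limits leave unreadable from compound 1 to compound 2, a step that the two limits leave unreadable from compound 1 to compound 3 and a step that the two limits leave unreadable from compound 2 to compound 3 are all unreadable for the same reason: both ends of each sit at a limit, so no size and no direction can be taken from them.

Compound 4 `N#CC1=C(N)Oc2c(N)cc3nc4ccccc4nc3c2C12C(=O)N(Cc1cnnn1-c1c(Cl)cc(Cl)cc1Cl)c1ccccc12` differs from compound 3 as follows: 2,4,6-trichlorophenyl in place of 2,6-difluorophenyl on an aromatic nitrogen. The measured steps that bear on this change are the three named above, since each of them also exchanges the aryl group on that aromatic nitrogen, and none of them yields a readable size. No value in the series lies inside the measured window, so there is nothing to point to a readable shift in either direction.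

Compound 4 is accordingly expected to give 80000 nM in this assay, with a range from 30000 nM to 300000 nM. The step from compound 3 to compound 4 is estimated at a step that the limit leaves unreadable from compound 3 to compound 4, that is, no step beyond the scatter, with another limit the most likely outcome.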

Compound 4, half-maximal inhibitory concentration: > 50000 nM
Compound 4 gave a limit, no number; the forecaster's own chance of this, stated with the estimate: 85%; the middle value lies beyond the limit too.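

In this assay compound 4 gives > 50000 nM, a limit and not a number. No step from compound 1, compound 2 or compound 3 to compound 4 can be read, and the series stays at one point: the limit of > 50000 nM in this assay, at which 4 of the 4 values shown sit.

The compounds shown leave open whether any aryl group on that aromatic nitrogen would give a readable value in this assay.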